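This account rests on a few compounds, and the source may have more. Where it says the series, first, only, none or still open, it means among the compounds named here.

Compound 1, with the structure `COc1ccc(CSc2nnc(-c3cc(OC)c(OC)c(OC)c3)n2-c2ccc(OC)cc2)cc1`, is the starting point. In a functional assay on HT-29 cells (Homo sapiens) for inhibition, read by MTT assay, with a stated time of 48 h (a higher number here means a weaker inhibitor, a lower number a stronger inhibitor), compound 1 gives > 60000 nM, which is a limit of the assay rather than a number. Two neighbours were measured alongside it. Compound 2, `COc1ccc(-n2c(SCC(=O)c3ccc(F)cc3)nnc2-c2cc(OC)c(OC)c(OC)c2)cc1`, gives 42500 nM in this assay. Compound 3, `CCOC(=O)CSc1nnc(-c2cc(OC)c(OC)c(OC)c2)n1-c1ccc(OC)cc1`, gives > 60000 nM in this assay, again a limit of the assay and not a number. The three values thus sit close together at the weak end: an at least 1.4-fold lower number from compound 1 to compound 2 (0.14 log units; that floor lies within the scatter), a step that the two limits leave unreadable from compound 1 to compound 3 and an at least 1.4-fold higher number from compound 2 to compound 3 (0.14 log units; that floor lies within the scatter), none of them readable as a change beyond the scatter, and the picture is summed up by the limit of > 60000 nM in this assay, at which 2 of the 3 values shown sit.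

The new compound 4 has the structure `COc1ccc(-n2c(SCC(=O)Nc3ccc(Cl)cc3)nnc2-c2cc(OC)c(OC)c(OC)c2)cc1`. It differs from compound 1 in one place: (4-chlorophenyl)carbamoyl in place of 4-methoxyphenyl on a saturated chain carbon bound to a sulfur. The steps from compound 1 to compound 2 and to compound 3 are the ones that bear on this change, and both replaced the same group on the same saturated chain carbon bound to a sulfur without moving the number beyond the scatter. Compound 4 is therefore expected to stay in the same weak region, with an at least 1.2-fold lower number from compound 1 to compound 4 (0.07 log units; that floor lies within the scatter) as the estimated step. The estimate for compound 4 in this assay is 50000 nM, in a range from 20000 nM to 120000 nM.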

Compound 4, half-maximal inhibitory concentration: 58000 nM
The estimate for compound 4 lay 1.2-fold (0.06 log units) below the measured number, within the range that was stated.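

Adding the amide hydrogen, the (4-chlorophenyl)carbamoyl group is a third kind of replacement for 4-methoxyphenyl on the saturated chain carbon bound to a sulfur, and it gives an at least 1.0-fold lower number from compound 1 to compound 4 (0.01 log units; that floor lies within the scatter). On the carbonyl carbon, (4-chlorophenyl)amino in place of ethoxy gives an at least 1.0-fold lower number from compound 3 to compound 4 (0.01 log units; that floor lies within the scatter), and (4-chlorophenyl)amino in place of 4-fluorophenyl gives a 1.4-fold higher number from compound 2 to compound 4 (0.14 log units; within the scatter), so an amide, an ester and a ketone at this place cannot be told apart in this assay. Compound 1 and compound 3 each stand at a limit of the assay and not at a number, so the true size of their steps stays hidden: the limit of > 60000 nM in this assay, at which 2 of the 4 values shown sit.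

The compounds shown leave open whether an amine, a carboxylic acid or a longer chain on the saturated chain carbon bound to a sulfur would move the number beyond the scatter. They also leave open whether any group at this place can matter while the rest of the shared core stays as it is in compound 1, since all four compounds sit at the weak end of this assay.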